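From 3-methylpiperidin-1-yl to cyclobutylmethoxy on a shared core

A few compounds are considered here, and "the series" means these few. Any claim that something is new, unique, unknown or untested is made for them only; others in the source may bear on it.

Compound 1 `CC1CCCN(c2cc(C(F)(F)F)nn2-c2ccc(S(C)(=O)=O)cn2)C1` offers no number to start from: in a physicochemical assay for solubility (on this read-out higher numbers stand for higher solubility and lower numbers for lower solubility), compound 1 is recorded as "not determined" (no result reported) and no result was reported. Among the measured compounds shown here, two related compounds supply the only readings. Compound 2 `CS(=O)(=O)c1ccc(-n2nc(C(F)F)c(C#N)c2NCC2CC2)cc1` gives > 200 ug/mL in this assay and that reading is a limit, not a number. Compound 3 `CS(=O)(=O)c1ccc(-n2nc(C(F)(F)F)cc2OC2CCCC2)cc1` gives 25 ug/mL as a plain number in this assay.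

Compound 4 `CS(=O)(=O)c1ccc(-n2nc(C(F)(F)F)cc2OCC2CCC2)nc1` keeps the core of compound 1 and carries cyclobutylmethoxy in place of 3-methylpiperidin-1-yl on an aromatic carbon, with the trifluoromethyl group left where it was. For the measured compounds named here, with no value for compound 1 and no measured pair that differs in one place, the size of this step in this assay cannot be read directly from the data. Compound 4 shares the trifluoromethyl group and an oxygen-linked carbon ring with compound 3 at 25 ug/mL in this assay, so no difference beyond the usual scatter from that reading is expected. For compound 4 the expected solubility is 20 ug/mL with an estimated range from 6 ug/mL to 60 ug/mL in this assay.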

Compound 4, solubility: 100 ug/mL
Estimate against measurement, compound 4: 5.0-fold (0.70 log units) below; the measured number lies above the stated range.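

No new step can be read from this result: compound 1 offers no number to compare in this assay, and compound 4 differs from compound 2 and compound 3 in more than one place. The compounds shown leave open what the exchange of 3-methylpiperidin-1-yl for cyclobutylmethoxy does on its own, and where compound 2 truly stands, its reading being a limit: the limit of > 200 ug/mL in this assay, at which 1 of the 4 values shown sits.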